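The source may hold more compounds than are shown below. What is called first, only, known or untested is meant among the compounds shown, and "the series" means these compounds.

Measured in an assay on isolated protein for inhibition of protein deacetylase HDAC6 (Homo sapiens), read by fluorescence, with a stated time of 1 h, tested at 100 nM; on this read-out lower numbers stand for less inhibition and higher numbers for more inhibition at the one concentration tested (going by the name of the read-out):
compound 1, `O=C(/C=C/c1ccc(OCc2nc(C3CCN(Cc4ccccc4)CC3)no2)cc1)NO`: 71%
compound 2, `O=C(/C=C/c1ccc(OCc2nc(C3CCN(Cc4ccc(F)cc4)CC3)no2)cc1)NO`: 75%
compound 3, `N#Cc1ccc(CN2CCC(c3noc(COc4ccc(/C=C/C(=O)NO)cc4)n3)CC2)cc1`: 65%

The three measured compounds share one core and differ only in the group on the benzyl carbon bound to the ring amine nitrogen. Compound 3 carries the nitrile there. Its number is the smallest of the three, but a number 6 percentage points lower from compound 1 to compound 3 (within the scatter) and a number 10 percentage points lower from compound 2 to compound 3 (within the scatter) both lie within the scatter, so compound 3 cannot be separated from compound 1 or compound 2 on these data. The remaining step, a number 4 percentage points higher from compound 1 to compound 2 (within the scatter), is likewise within the scatter: hydrogen, fluoro and cyano on that aromatic carbon give indistinguishable read-outs.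

Compound 4, `O=C(/C=C/c1ccc(OCc2nc(C3CCN(Cc4ccccc4[N+](=O)[O-])CC3)no2)cc1)NO`, is not yet measured. 2-nitrophenyl in place of 4-cyanophenyl on a saturated chain carbon bound to an amine nitrogen in a ring

All three known steps bear on this change in that they alter the same aryl group on the same saturated chain carbon, and none of them moved the read-out beyond the scatter. For the measured compounds named here, no measured compound carries a nitro group, so the 2-nitrophenyl has no direct precedent here. On the evidence of those three flat steps, compound 4 is expected to stay close to compound 3, with a number 3 percentage points higher from compound 3 to compound 4 (within the scatter) expected to be within the scatter and with no direction preferred. Compound 4 is therefore estimated at 68%, in the range 50% to 82%.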

Compound 4, a percentage reported as inhibition, at one concentration (the size of the read-out at that concentration, not a potency): 63%
Estimate against measurement, compound 4: 5 percentage points above; low and high end bracket the measured number.
By their numbers in this assay, from the lowest: compounds 4, 3, 1 and 2 (each within the scatter of the next, the first and the last beyond it).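

In this assay, for the compounds shown here, the 2-nitrophenyl group gives the first step at this position that is beyond the scatter, a number 12 percentage points lower from compound 2 to compound 4 (beyond the scatter), so the aryl group on the saturated chain carbon bound to an amine nitrogen in a ring is not wholly without bearing on the read-out, although that step is modest. The other two steps, a number 2 percentage points lower from compound 3 to compound 4 (within the scatter) and a number 8 percentage points lower from compound 1 to compound 4 (within the scatter), stay within the scatter, so compound 4 separates from compound 2 alone and cannot be told apart from the 4-cyanophenyl of compound 3 or the unsubstituted benzyl of compound 1. Nothing in the material shown accounts for the one step that does stand out.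

On these data alone, it stays open whether that step follows the nitro group itself or the place it occupies on the ring, a question that a 4-nitrophenyl group would address. Also open, as far as these compounds go, is how an aminophenyl or carboxyphenyl group, or a longer chain in place of the benzyl carbon, would read in this assay, and since only one concentration is reported, the potencies of all four compounds remain unknown.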